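The source may report more compounds than this note shows. Statements on the series, on what has been measured and on what is new or still open speak of the compounds shown alone.

Compound 1 `COc1cc(-c2cc(/C=C/C(=O)c3ccc(Cl)c(Cl)c3)[nH]n2)cc(OC)c1OC`: 97%
Compound 2 `COc1ccc(C(=O)/C=C/c2cc(-c3cc(OC)c(OC)c(OC)c3)n[nH]2)cc1OC`: 101%

In a functional assay on OVCAR-5 cells (Homo sapiens) for cytotoxicity, read by sulforhodamine B assay, with a stated time of 48 h, tested at 0.01 uM (on this read-out higher numbers stand for a weaker effect at the one concentration tested and lower numbers for a stronger effect), compound 1 gives 97% and compound 2 gives 101%. Compound 2 holds the higher of these two numbers, yet the two lie level, since a number 4 percentage points higher from compound 1 to compound 2 (within the scatter). Both readings say that, at this one concentration, the cells are barely touched.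

Compound 3 `COc1cc(C(=O)/C=C/c2cc(-c3cc(OC)c(OC)c(OC)c3)n[nH]2)cc(OC)c1OC` has not been measured yet. Its change from compound 2 is methoxy in place of hydrogen on an aromatic carbon. Within the data shown here, the single measured step, swapping the whole aryl group on the carbonyl carbon, moved the number only within the scatter, and no step touching the methoxy pattern of this ring has been measured at all. The present change is smaller than that swap, so no step beyond the scatter is expected in this assay.

Compound 3 is therefore expected to read about 99%, between 85% and 110%, which is an expected step of a number 2 percentage points lower from compound 2 to compound 3 (within the scatter).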

Compound 3, a percentage reported as activity, at one concentration (the size of the read-out at that concentration, not a potency): 97%
Compound 3: the middle estimate sits 2 percentage points above what was measured; the range from low to high includes it.
By their numbers in this assay, from the lowest: compounds 1, 3 and 2 (each within the scatter of the next).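

Putting methoxy in place of hydrogen on an aromatic carbon, ortho to a methoxy group and meta to a large group, gives a number 4 percentage points lower from compound 2 to compound 3 (within the scatter) in this assay. Among these compounds, this is the first measured step at this position of the ring, and it shows that the added methoxy leaves compound 3 level with compound 2 at this one low concentration, with the cells still barely touched. Nothing at hand offers any explanation of this reading.

As far as these compounds go, whether compound 2 and compound 3 would separate at higher concentrations remains open, since a single-concentration reading gives no potency. From the compounds shown here alone, it is also open whether a different group at this position, such as an amine or a carboxylic acid, would move the number beyond the usual scatter.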